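The compounds below may be only part of what the source reports. "The series", "measured", "known", "first", "only" and "open" are said of these compounds alone.

The measured compounds in a functional assay on the whole organism for activation, with Mus musculus as the target; on this read-out lower numbers stand for an effect already at smaller amounts and higher numbers for an effect only at larger amounts of compound:
compound 1, `Cc1nc(N)c2nc(O)n(Cc3ccccc3)c2n1`, gives 3 mg/kg;
compound 2, `Nc1nc(O)nc2c1nc(O)n2Cc1ccccc1`, gives 1 mg/kg;
compound 3, `CCSc1nc(N)c2nc(O)n(Cc3ccccc3)c2n1`, gives 0.1 mg/kg.

Among these three, compound 3 stands lowest, separated from the others by a 10-fold lower number from compound 2 to compound 3 (1.00 log units; beyond the scatter) and by a 30-fold lower number from compound 1 to compound 3 (1.48 log units; beyond the scatter). Compound 4, `CCCCc1nc(N)c2nc(O)n(Cc3ccccc3)c2n1`, differs from compound 3 by butyl in place of ethylsulfanyl on an aromatic carbon. Among the measured compounds shown here, the steps that bear on this change are the ones that brought in the ethylsulfanyl group, a 30-fold lower number from compound 1 to compound 3 (1.48 log units; beyond the scatter) and a 10-fold lower number from compound 2 to compound 3 (1.00 log units; beyond the scatter): that group goes with the lowest number seen, whereas the only other alkyl group, methyl in compound 1, goes with the highest. No alkyl chain longer than methyl has been measured. Compound 4 is therefore expected to fall between these cases, with an estimated step of a 5.0-fold higher number from compound 3 to compound 4 (0.70 log units; beyond the scatter) toward a higher number. The estimate for compound 4 in this assay is 0.5 mg/kg, ranging from 0.1 mg/kg to 3 mg/kg.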

Compound 4, minimum effective dose: 0.3 mg/kg
For compound 4 the middle estimate is 1.7-fold (0.22 log units) above the measured one, within the range that was stated.
By their numbers in this assay, from the lowest: compound 3; then compound 4; then compound 2; then compound 1.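

In this assay, lengthening the alkyl chain at this position from methyl to butyl gives a 10-fold lower number from compound 1 to compound 4 (1.00 log units; beyond the scatter), and butyl in place of hydroxy gives a 3.3-fold lower number from compound 2 to compound 4 (0.52 log units; beyond the scatter), so a chain without sulfur also reaches a low number. Ethylsulfanyl still holds the lowest place, since the change to butyl gives a 3.0-fold higher number from compound 3 to compound 4 (0.48 log units; beyond the scatter). Nothing available explains these steps. The compounds shown leave open whether chain length or the sulfur atom matters more here, and how propylsulfanyl, hexyl or an amine would compare at this position.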